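Sulfonyl aryl variation in the K562 series

This account rests on a few compounds, and the source may have more. Where it says the series, first, only, none or still open, it means among the compounds named here.

Among the compounds with values here, compound 3 `COc1ccc(S(=O)(=O)c2cc3cnc(Nc4ccc5[nH]ccc5c4)nc3n(C)c2=O)cc1` holds the lowest number of the three measured members. In a functional assay on K562 cells (Homo sapiens) for inhibition, read by trypan blue exclusion, with a stated time of 72 h (a higher number here means a weaker inhibitor, a lower number a stronger inhibitor), compound 3 gives 300 nM, while compound 2 `Cc1ccc(S(=O)(=O)c2cc3cnc(Nc4ccc5[nH]ccc5c4)nc3n(C)c2=O)cc1` gives 750 nM and compound 1 `Cn1c(=O)c(S(=O)(=O)c2ccc(C(=O)O)cc2)cc2cnc(Nc3ccc4[nH]ccc4c3)nc21` gives 5000 nM. Within the data shown here, all three steps so far change the group on the aryl ring attached to the sulfonyl sulfur: a 17-fold lower number from compound 1 to compound 3 (1.22 log units; beyond the scatter), a 6.7-fold lower number from compound 1 to compound 2 (0.82 log units; beyond the scatter) and a 2.5-fold lower number from compound 2 to compound 3 (0.40 log units; beyond the scatter). Every replacement of the carboxy group has lowered the number, and methoxy did so more than methyl.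

Compound 4 `Cn1c(=O)c(S(=O)(=O)c2ccc(N)cc2F)cc2cnc(Nc3ccc4[nH]ccc4c3)nc21` alters the same ring again: 4-amino-2-fluorophenyl in place of 4-methoxyphenyl on a sulfonyl sulfur. Among the measured compounds shown here, no measured step touches an amino or a fluorine on this ring, so the earlier steps show only that this position moves the number by modest to large amounts; they do not fix the direction for a donor-bearing ring. The step is therefore expected to stay near the scatter, with a slight lean to a higher number, a 1.3-fold higher number from compound 3 to compound 4 (0.12 log units; within the scatter). Compound 4 is estimated at 400 nM in this assay, within 150 nM to 1200 nM.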

Compound 4, half-maximal inhibitory concentration: 1500 nM
Compound 4: the middle estimate sits 3.8-fold (0.57 log units) below what was measured, outside the stated range (above it).
By their numbers in this assay, from the lowest: compound 3; then compounds 2 and 4 (each within the scatter of the next); then compound 1.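

In this assay the new ring gives a 5.0-fold higher number from compound 3 to compound 4 (0.70 log units; beyond the scatter) and so does not hold the level of 4-methoxyphenyl on this sulfonyl sulfur, which shows that a ring with a hydrogen-bond donor can sit on the higher side of the methoxy ring. Against 4-methylphenyl there is a 2.0-fold higher number from compound 2 to compound 4 (0.30 log units; within the scatter) and no order can be drawn, while a 3.3-fold lower number from compound 1 to compound 4 (0.52 log units; beyond the scatter) shows that the new ring still improves on 4-carboxyphenyl, so replacing the carboxy group has now lowered the number in all three cases. Nothing on hand accounts for the rise from the methoxy ring.

From the compounds shown here alone, the amino group and the fluorine enter together, so their separate shares in the step stay open; a ring carrying either one alone would divide them. Going by these compounds, whether a dimethylamino group or a chlorine on this ring would lie nearer the methoxy ring also stays open.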